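The source may report more compounds than this note shows. Statements on the series, on what has been measured and on what is new or still open speak of the compounds shown alone.

Working notes on the series. Within the data shown here, in a functional assay on HeLa cells (Homo sapiens) for cytotoxicity, read by sulforhodamine B assay (a higher number here means a weaker inhibitor, a lower number a stronger inhibitor), compound 3 `COc1ccc(S(=O)(=O)NC(C)C2=CC(=O)c3c(O)ccc(O)c3C2=O)c(OC)c1` gives 19500 nM, the highest of the three numbers so far, which makes it the weakest inhibitor of the set. Compound 1 `CC(C)C(NS(=O)(=O)c1ccc(F)cc1)C1=CC(=O)c2c(O)ccc(O)c2C1=O` gives 6650 nM and compound 2 `Cc1ccccc1S(=O)(=O)NC(C)C1=CC(=O)c2c(O)ccc(O)c2C1=O` gives 4490 nM, two values within the scatter of each other.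

Compound 4 `CC(NS(=O)(=O)c1ccc(F)cc1)C1=CC(=O)c2c(O)ccc(O)c2C1=O` differs from compound 3 in one place: 4-fluorophenyl in place of 2,4-dimethoxyphenyl on a sulfonyl sulfur. This puts 4-fluorophenyl in place of 2,4-dimethoxyphenyl on a sulfonyl sulfur.

Among the measured compounds shown here, the only measured step at this place is a 4.3-fold higher number from compound 2 to compound 3 (0.64 log units; beyond the scatter), where 2,4-dimethoxyphenyl replaced 2-methylphenyl and the number rose. Though it differs from compound 4 elsewhere, compound 1 also carries 4-fluorophenyl on the sulfonyl sulfur, and compound 1 gives 6650 nM, which lies under the value of compound 3. Leaving 2,4-dimethoxyphenyl is therefore expected to give a modest step of similar size in this assay, towards a lower number and a stronger inhibitor. The expected change is a 3.3-fold lower number from compound 3 to compound 4 (0.51 log units; beyond the scatter). For compound 4 the estimated value is 6000 nM, with an expected range of 2500 nM to 14000 nM.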

Compound 4, half-maximal inhibitory concentration: 6410 nM
For compound 4 the middle estimate is 1.1-fold (0.03 log units) below the measured one; the measured number falls inside the stated range.
By their numbers in this assay, from the lowest: compounds 2, 4 and 1 (each within the scatter of the next); then compound 3.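

In this assay, the step to 4-fluorophenyl on the sulfonyl sulfur (a 3.0-fold lower number from compound 3 to compound 4 (0.48 log units; beyond the scatter)) gives a second comparison at this place beyond the scatter, so compound 3 now stands apart from both compound 2 and compound 4. The two groups without methoxy, 2-methylphenyl and 4-fluorophenyl, are not separated here (a 1.4-fold higher number from compound 2 to compound 4 (0.15 log units; within the scatter)). With 4-fluorophenyl held fixed, methyl in place of isopropyl on the saturated chain carbon is also not separated (a 1.0-fold lower number from compound 1 to compound 4 (0.02 log units; within the scatter)).

No measurement shown bears on why compound 3 stands apart. Still open, on these data alone, are whether a phenyl carrying a single methoxy group would stand with compound 3 or with compound 4, and how an unsubstituted phenyl on the sulfonyl sulfur or a longer chain on the saturated chain carbon would read.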